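The source may report more compounds than this note shows. Statements on the series, on what has been measured and on what is new or still open speak of the compounds shown alone.

Compound 1 `CC(C)[N+]1(C)CCc2c(sc(NC(=O)Nc3ccc(Cl)cc3)c2C(N)=O)C1`: 960 nM
Compound 2 `NC(=O)c1c(NC(=O)Nc2ccc(Cl)cc2)sc2c1CCN(CC1CCCCC1)C2`: 1890 nM

Of the compounds shown here, two have so far been measured in a functional assay (strain AB) with Danio rerio as the target, read by microscopy, with a stated time of 1 h; on this read-out higher numbers stand for an effect only at larger amounts of compound and lower numbers for an effect already at smaller amounts. Compound 1 gives 960 nM, and compound 2 gives 1890 nM. Compound 1 holds the lowest of the two numbers, but its gap to compound 2 lies within the scatter, so the two compounds cannot be told apart on these data. Compound 3 `CC[N+]1(C)CCc2c(sc(NC(=O)Nc3ccc(Cl)cc3)c2C(N)=O)C1` has not yet been measured in this assay. It differs from compound 1 by hydrogen in place of methyl on a saturated chain carbon bound to an amine nitrogen in a ring and a saturated chain carbon. Among the measured compounds shown here, no step between measured compounds carries this change, so its size can only be guessed from the two numbers at hand. The step from compound 1 to compound 3 is estimated as a 1.4-fold higher number from compound 1 to compound 3 (0.13 log units; within the scatter), leaning toward a somewhat higher number, although a result within the scatter is fully possible. Compound 3 is therefore expected to give 1300 nM, with a range from 500 nM to 3500 nM.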

Compound 3, half-maximal effective concentration: 1960 nM
For compound 3 the middle estimate is 1.5-fold (0.18 log units) below the measured one; the range from low to high includes it.
By their numbers in this assay, from the lowest: compounds 1, 2 and 3 (each within the scatter of the next, the first and the last beyond it).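

Replacing isopropyl with ethyl on a saturated chain carbon bound to an amine nitrogen in a ring and a saturated chain carbon gives, in this assay, a 2.0-fold higher number from compound 1 to compound 3 (0.31 log units; beyond the scatter). This is the only step shown between compounds that differ in one place, and it shows that the read-out responds, modestly, to the loss of a single methyl at this position, a change that the earlier pair of values could not isolate. Nothing available explains why this change moves the number.

The compounds shown leave open what a shorter methyl, a larger tert-butyl or a longer n-propyl chain would give at this place. A single step also cannot show whether the number follows the size of the group in any regular way.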